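The compounds below may be only part of what the source reports. "The series", "measured", "known", "first", "only" and "open" are said of these compounds alone.

Measured so far:
compound 1 `CCSC(=S)SCC(=O)c1ccc(C)cc1` gives 3980 nM
compound 2 `CCSC(=S)SCC(=O)c1ccc(S(N)(=O)=O)cc1` gives 20000 nM

For the measured compounds named here, compound 2 stands highest of the two in a functional assay on HeLa cells (Homo sapiens) for antiproliferative activity, read by resazurin assay (a higher number here means a weaker inhibitor, a lower number a stronger inhibitor), with 20000 nM and has compound 1 as its only and nearest neighbour. Compound 3 `CCSC(=S)SCC(=O)c1ccc(Cl)cc1` carries chloro in place of sulfamoyl on an aromatic carbon. Going by the values given here, the only measured step bearing on this change is a 5.0-fold higher number from compound 1 to compound 2 (0.70 log units; beyond the scatter) for sulfamoyl in place of methyl, modest but beyond the scatter. Among the compounds with values here, with compound 1 at 3980 nM as the guide, a step of similar size toward a lower number is expected for compound 3 in this assay although chloro is not methyl and no chloro compound has been measured yet. The expected step is a 4.4-fold lower number from compound 2 to compound 3 (0.65 log units; beyond the scatter) by this estimate. For compound 3 the estimated value is 4500 nM with an expected range from 1600 nM to 12000 nM in this series.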

Compound 3, half-maximal inhibitory concentration: 5010 nM
Compound 3: middle estimate off by 1.1-fold (0.05 log units), on the low side; low and high end bracket the measured number.
By their numbers in this assay, from the lowest: compounds 1 and 3 (each within the scatter of the next); then compound 2.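

In this assay, chloro in place of sulfamoyl gives a 4.0-fold lower number from compound 2 to compound 3 (0.60 log units; beyond the scatter), which shows that the weaker reading of compound 2 does not extend to every group replacing methyl at this aromatic carbon. Chloro in place of methyl gives a 1.3-fold higher number from compound 1 to compound 3 (0.10 log units; within the scatter), within the scatter, so compound 1 and compound 3 cannot be ordered, and sulfamoyl is the only one of the three groups that separates from the other two in this series. No measured evidence is available to explain this separation.

From the compounds shown here alone, whether an amine, a carboxylic acid or a methoxy group at this aromatic carbon would read with compound 2 or with compound 1 and compound 3 remains open. Also open, going by these compounds, is whether these steps would hold with a longer chain in place of the ethyl group of the shared core.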